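The source may hold more compounds than are shown below. What is called first, only, known or untested is meant among the compounds shown, and "the series" means these compounds.

Of the compounds shown here, two have so far been measured in a functional assay on MCF7 cells (Homo sapiens) for inhibition, read by CCK-8 assay, with a stated time of 48 h; a higher number here means a weaker inhibitor of growth, a lower number a stronger inhibitor of growth. Compound 1 `Cc1ccccc1Nc1nc(NCc2ccncc2)ncc1Cl` gives only a limit of the assay, > 100000 nM, and no number. Compound 2 `COc1ccccc1CNc1nc(Nc2ccc(N3CCN(C)CC3)cn2)ncc1Cl` likewise gives only a limit, > 100000 nM, in this assay. Both results sit at the same place, (the limit of > 100000 nM in this assay, at which 2 of the 2 values shown sit), so compound 2 stands at the upper edge of what this assay can report, with no measured number to set it apart from compound 1. Within the data shown here, no pair of these measured compounds differs in just one place, so no measured step is known.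

Compound 3 `COc1cccc(Nc2nc(Nc3ccc(N4CCN(C)CC4)cn3)ncc2Cl)c1` is not yet measured. It differs from compound 2 by one change, (3-methoxyphenyl in place of 2-methoxybenzyl on a nitrogen on an aromatic ring). With both measured compounds at the limit, nothing measured points to a gain or loss of growth inhibition from this change, and no shift beyond the scatter is expected, a number no higher from compound 2 to compound 3 (the limit leaves the size open). Compound 3 is therefore expected to give roughly 100000 nM in this assay, most likely between 30000 nM and 300000 nM, and quite possibly again only a limit.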

Compound 3, concentration for 50% growth inhibition: 7540 nM
Estimate against measurement, compound 3: 13-fold (1.12 log units) above; measured number outside the range, below it.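

In this assay, the nitrogen on the aromatic ring turns out to be a place where the attached group matters: putting 3-methoxyphenyl in place of 2-methoxybenzyl there gives an at least 13-fold lower number from compound 2 to compound 3 (1.12 log units; beyond the scatter), a large step beyond the scatter. Compound 3, at 7540 nM, is the only compound shown with a real number, so the compounds shown are no longer all stuck at the upper edge of what this assay can report. From the compounds shown here alone, the result for compound 2, > 100000 nM, is a limit and not a number, so the true size of the step stays unknown and could be larger: the limit of > 100000 nM in this assay, at which 2 of the 3 values shown sit.

Two things change together here, as benzyl gives way to phenyl and 2-methoxy gives way to 3-methoxy, and the compounds shown cannot separate the two. A 2-methoxyphenyl or a 3-methoxybenzyl group on the same nitrogen would tell them apart, while a plain phenyl group or a longer chain such as 2-phenylethyl would show whether the methoxy group is needed at all.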